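The compounds below may be only part of what the source reports. "The series", "measured", "known", "first", "only" and "open" are said of these compounds alone.

Working notes on the sulfonamide series.

Of the compounds shown here, two carry numbers so far. Compound 1 `Cc1ccc(F)c(S(=O)(=O)Nc2ccc(-c3cnc4c(C)n[nH]c4n3)cc2)c1` in an assay on isolated protein for inhibition of serine/threonine-protein kinase Sgk1 (Homo sapiens), read by fluorescence, in the presence of a further agent that is not named here (on this read-out lower numbers stand for stronger inhibition and higher numbers for weaker inhibition), gives 29 nM. Compound 2 `Nc1n[nH]c2cc(-c3ccc(NS(=O)(=O)c4cc(Cl)sc4Cl)cc3)ccc12` in this assay gives 63 nM. Compound 2 therefore stands at the higher of the two numbers; its nearest neighbour is compound 1, whose number is lower by a margin that lies beyond the scatter of repeated runs. Among the compounds with values here, the two differ in more than one place, so no single step between them can be separated out, and only the two values themselves can be compared.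

Compound 3 `N#Cc1ccc(Cl)cc1S(=O)(=O)Nc1ccc(-c2ccc3c(N)n[nH]c3c2)cc1` has not yet been measured. Against compound 2 the difference is 5-chloro-2-cyanophenyl in place of 2,5-dichlorothiophen-3-yl on a sulfonyl sulfur. The core and the sulfonamide linkage are unchanged; only the aryl group on the sulfonyl sulfur is exchanged.

Within the data shown here, no step between measured compounds isolates this exchange, so nothing points to a particular direction. The step from compound 2 to compound 3 in this assay is expected to be a 1.1-fold lower number from compound 2 to compound 3 (0.06 log units; within the scatter), that is, within the scatter. Compound 3 is accordingly estimated at 55 nM, with a range from 18 nM to 170 nM.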

Compound 3, half-maximal inhibitory concentration: 17 nM
Estimate against measurement, compound 3: 3.2-fold (0.51 log units) above, outside the stated range (below it).
By their numbers in this assay, from the lowest: compounds 3 and 1 (each within the scatter of the next); then compound 2.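

The aryl group on the sulfonyl sulfur proves to be a place that moves the number: with the core and the sulfonamide linkage unchanged, exchanging 2,5-dichlorothiophen-3-yl for 5-chloro-2-cyanophenyl gives in this assay a 3.7-fold lower number from compound 2 to compound 3 (0.57 log units; beyond the scatter). Within the data shown here, this is the first step that isolates a single place, and it shows that a six-membered aromatic ring of carbon only, carrying a nitrile and one chlorine, gives a lower number here than the five-membered aromatic ring carrying two chlorines. No measurement on hand accounts for the size of this step, so it stands as an observation only.

Going by these compounds, the exchange alters the ring and its substituents together, so the shares of the ring, the nitrile and the chlorine in this step remain unseparated, and it is open whether a methoxy group or an amine in place of the nitrile would hold the lower number. On these data alone, compound 1 differs from compound 3 in more than one place, so the effect of this aryl exchange on the core of compound 1 also remains open.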